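A few compounds are considered here, and "the series" means these few. Any claim that something is new, unique, unknown or untested is made for them only; others in the source may bear on it.

In an assay for inhibition of ribosomal protein S6 kinase beta-1 variant D18H,T412E (Homo sapiens), read by a luciferase reporter and chemiluminescence, with a stated time of 3 h (a higher number here means a weaker inhibitor, a lower number a stronger inhibitor), compound 3 `Cc1ccc(Cl)cc1N1CCN(c2ncnc3[nH]nc(C)c23)CC1` gives 9 nM, the lowest of the two numbers shown, though its gap to compound 2 is within the scatter. Compound 2 `Cc1ccc(Cl)cc1N1CCN(c2ncnc3[nH]ncc23)CC1` gives 13 nM in this assay, and the step of a 1.4-fold lower number from compound 2 to compound 3 (0.16 log units; within the scatter) is within the scatter. Compound 1 `Nc1cc(N2CCN(c3cccc(Cl)c3)CC2)ncn1` reaches only the limit > 2000 nM in this assay; this is a limit of the measurement, not a number. Compound 4 `CCc1n[nH]c2ncnc(N3CCN(c4cc(Cl)ccc4C)CC3)c12` differs from compound 3 by methyl in place of hydrogen on a saturated chain carbon bound to an aromatic carbon. Within the data shown here, the one measured step that compares, the added methyl from compound 2 to compound 3, was within the scatter, so no step beyond the scatter is expected in this assay for compound 4. Compound 4 is therefore expected at 9 nM, between 3 nM and 27 nM, a step of no change at the digits printed from compound 3 to compound 4 (within the scatter).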

Compound 4, half-maximal inhibitory concentration: 6 nM
The estimate for compound 4 lay 1.5-fold (0.18 log units) above the measured number, and the stated range covers the measured number.
By their numbers in this assay, from the lowest: compounds 4, 3 and 2 (each within the scatter of the next, the first and the last beyond it). At a limit, above all of these: compound 1.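

Going from methyl to ethyl on this position leaves the number within the scatter, with a 1.5-fold lower number from compound 3 to compound 4 (0.18 log units; within the scatter) in this assay. Among these compounds, measured against hydrogen, however, ethyl gives a 2.2-fold lower number from compound 2 to compound 4 (0.34 log units; beyond the scatter) and so provides the first step at this position to clear the scatter, though only modestly. Nothing shown here explains either step. On these data alone, whether a longer chain such as propyl, a small ring such as cyclopropyl, or an amine would be tolerated on this position stays open. So does whether the number would keep falling as the group grows.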